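From a hydroxypentyl chain to a phenyl ring

The source may report more compounds than this note shows. Statements on the series, on what has been measured and on what is new or still open speak of the compounds shown alone.

The compounds here share one core and differ only in the group attached to a nitrogen on an aromatic ring. Compound 1 `CSc1nc(NCCCCCO)c2ccccc2n1` carries a 5-hydroxypentyl chain there. In a functional assay on HT-29 cells (Homo sapiens) for cytotoxicity, read by MTT assay, with a stated time of 72 h (a higher number here means a weaker inhibitor of growth, a lower number a stronger inhibitor of growth), compound 1 gives only a limit, > 100000 nM. Compound 1 therefore sits at the limit of > 100000 nM in this assay, at which 1 of the 3 values shown sits. Compound 2 `COc1ccc(CNc2nc(SC)nc3ccccc23)cc1` gives 70200 nM in this assay, and compound 3 `CSc1nc(NCCCc2ccccc2)c2ccccc2n1` gives 19600 nM. For the measured compounds named here, the one measured step that bears on the question, an at least 5.1-fold lower number from compound 1 to compound 3 (0.70 log units; beyond the scatter), points toward lower numbers when phenyl enters in place of a hydroxyl-bearing group. Compound 4 `CSc1nc(Nc2ccccc2)c2ccccc2n1` is not yet measured; it differs from compound 1 by phenyl in place of 5-hydroxypentyl on a nitrogen on an aromatic ring, so the whole 5-hydroxypentyl chain gives way to phenyl, and the entering phenyl has no hydrogen-bond donor or acceptor. Because the step of an at least 5.1-fold lower number from compound 1 to compound 3 (0.70 log units; beyond the scatter) was beyond the scatter, a move in the same direction is expected here. For compound 4 the expected value is 30000 nM, between 8000 nM and 100000 nM, which means an expected at least 3.3-fold lower number from compound 1 to compound 4 (0.52 log units; beyond the scatter).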

Compound 4, concentration for 50% growth inhibition: 65800 nM
Beside the measured number, compound 4's estimate is 2.2-fold (0.34 log units) below it; low and high end bracket the measured number.
By their numbers in this assay, from the lowest: compound 3; then compounds 4 and 2 (each within the scatter of the next). At a limit, above all of these: compound 1.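

Here the whole 5-hydroxypentyl chain gives way to phenyl on a nitrogen on an aromatic ring, with the heavy-atom count unchanged at 6, and the step reads an at least 1.5-fold lower number from compound 1 to compound 4 (0.18 log units; that floor lies within the scatter). For compound 1, > 100000 nM is a limit of the assay and not a number. In this assay compound 4 gives 65800 nM and compound 3, which carries its phenyl on a saturated chain, gives 19600 nM, so phenyl set directly on that nitrogen does not reach the number of compound 3.

On these data alone, how far compound 4 truly lies from compound 1 stays open because compound 1 stands at a limit: the limit of > 100000 nM in this assay, at which 1 of the 4 values shown sits. Also open, as far as these compounds go, is how a chain ending in an amine or a carboxylic acid, or a longer chain carrying the phenyl, would read at this nitrogen.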